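Ring-closing the amine tail of a sulfonyl pyrrolidine carboxamide

The source may hold more compounds than are shown below. What is called first, only, known or untested is meant among the compounds shown, and "the series" means these compounds.

Compound 1, with the structure `Cc1ccc2[nH]c(C(=O)N[C@H]3CN(S(=O)(=O)c4ccccc4)C[C@@H]3C(=O)NCCN(C)C)cc2c1`, is tested in a functional assay on HEK293 cells for agonist activity at growth hormone secretagogue receptor type 1 (Homo sapiens), read by HTRF and inositol phosphate accumulation, with a stated time of 90 min, in the presence of a further agent that is not named here (a lower number here means a smaller maximal response, a higher number a larger maximal response), where compound 1 gives 93%. Among the compounds with values here, that figure is the second highest of the three numbers known. Compound 2 `Cc1ccc2[nH]c(C(=O)N[C@H]3CN(S(=O)(=O)c4cn(C)nc4C)C[C@@H]3C(=O)NCCN(C)C)cc2c1` carries 1,3-dimethyl-1H-pyrazol-4-yl in place of phenyl on a sulfonyl sulfur; in this assay compound 2 gives 95%, and the step of a number 2 percentage points higher from compound 1 to compound 2 (within the scatter) stays within the scatter. Compound 3 `Cc1ccc2[nH]c(C(=O)N[C@H]3CN(S(=O)(=O)c4ccccc4)C[C@H]3C(=O)NCCN(C)C)cc2c1` has the same atoms and bonds as compound 1 and differs only in configuration as drawn, as noted in the fact that compounds 1 and 3 differ only in the configuration as drawn; in this assay compound 3 gives 72%, so the step of a number 21 percentage points lower from compound 1 to compound 3 (beyond the scatter) is the only one beyond the scatter.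

Compound 4 `Cc1ccc2[nH]c(C(=O)N[C@H]3CN(S(=O)(=O)c4ccccc4)C[C@@H]3C(=O)NC[C@@H]3CCCN3C)cc2c1` is not yet measured. Relative to compound 1 the change is 1-methylpyrrolidin-2-yl in place of (dimethylamino)methyl on a saturated chain carbon bound to an amide-type nitrogen. Within the data shown here, neither measured step touches this part of the molecule: the first alters the sulfonyl aryl group and the second only the drawn configuration, so no direct precedent exists for this exchange. Both compounds keep the same configuration and the same sulfonyl phenyl as compound 1, and compound 4 is therefore expected to show no step beyond the scatter, with an estimated step of a number 3 percentage points lower from compound 1 to compound 4 (within the scatter). In this assay compound 4 is estimated at 90%, within a range from 75% to 102%.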

Compound 4, largest response reached (Emax), in percent of the reference or control that the assay uses: 87%
Compound 4: the middle estimate sits 3 percentage points above what was measured; low and high end bracket the measured number.
By their numbers in this assay, from the lowest: compound 3; then compounds 4, 1 and 2 (each within the scatter of the next).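

In this assay, within the data shown here, putting 1-methylpyrrolidin-2-yl in place of (dimethylamino)methyl on a saturated chain carbon bound to an amide-type nitrogen gives a step of a number 6 percentage points lower from compound 1 to compound 4 (within the scatter), the first reading at this position. Among these compounds, it shows that, in this one pair, the open amine tail can be replaced by a five-membered non-aromatic ring carrying a defined stereocentre with no change in the largest response beyond the scatter, whereas the earlier compounds spoke only to the sulfonyl aryl group and to the drawn configuration of the shared core, where the step of a number 21 percentage points lower from compound 1 to compound 3 (beyond the scatter) is the one that leaves the scatter. Nothing known here gives a cause for this result.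

The compounds shown leave open how the opposite configuration at the new stereocentre of the 1-methylpyrrolidin-2-yl group would read, and whether a piperidine, a primary amine, a carboxylic acid or a longer chain at this place would stay within the scatter as well. They also leave open whether the ring-closed tail would read the same alongside 1,3-dimethyl-1H-pyrazol-4-yl on the sulfonyl sulfur.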